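Methoxy for bromo on the aryl-triazole of compound 1

The source may hold more compounds than are shown below. What is called first, only, known or untested is meant among the compounds shown, and "the series" means these compounds.

The measured compounds are:
compound 1, `O=C1O[C@H]([C@@H](O)Cn2cc(-c3ccc(Br)cc3)nn2)C(OCc2ccccc2)=C1OCc1ccccc1`, 5620 nM;
compound 2, `O=C1O[C@H]([C@@H](O)Cn2cc(C3CC3)nn2)C(OCc2ccccc2)=C1OCc1ccccc1`, 25900 nM;
compound 3, `O=C1O[C@H]([C@@H](O)Cn2cc(-c3cc(F)cc(F)c3)nn2)C(OCc2ccccc2)=C1OCc1ccccc1`, 27700 nM.

In a functional assay on MCF7 cells (Homo sapiens) for antiproliferative activity, read by MTT assay, with a stated time of 72 h (a higher number here means a weaker inhibitor, a lower number a stronger inhibitor), compound 1 gives the lowest number of the three, with compound 2 the nearest to it and compound 3 the furthest away. Both steps leaving compound 1 move in the same direction: a 4.6-fold higher number from compound 1 to compound 2 (0.66 log units; beyond the scatter) and a 4.9-fold higher number from compound 1 to compound 3 (0.69 log units; beyond the scatter). Between compound 2 and compound 3 the gap is a 1.1-fold higher number from compound 2 to compound 3 (0.03 log units; within the scatter).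

Compound 4, `COc1ccc(-c2cn(C[C@H](O)[C@H]3OC(=O)C(OCc4ccccc4)=C3OCc3ccccc3)nn2)cc1`, differs from compound 1 by methoxy in place of bromo on an aromatic carbon. Neither measured step tests this change directly. One replaces the 4-bromophenyl with cyclopropyl, the other with 3,5-difluorophenyl, and each costs a modest amount; the 4-bromophenyl to 4-methoxyphenyl change keeps the phenyl ring and alters only the group on it. The two earlier steps therefore bear only loosely on this one, and a step no larger than theirs is expected in this assay, most likely toward a higher number but possibly none beyond the scatter. The expected step is a 1.6-fold higher number from compound 1 to compound 4 (0.20 log units; within the scatter). Compound 4 is estimated at 9000 nM, within 3000 nM to 30000 nM.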

Compound 4, half-maximal inhibitory concentration: 99700 nM
Compound 4: middle estimate off by 11-fold (1.04 log units), on the low side; measured number above the stated range.
By their numbers in this assay, from the lowest: compound 1; then compounds 2 and 3 (each within the scatter of the next); then compound 4.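

With the phenyl ring kept and only the group on it exchanged, this assay shows an 18-fold higher number from compound 1 to compound 4 (1.25 log units; beyond the scatter) as a large step, larger than either earlier step, each of which replaced the whole 4-bromophenyl. Keeping the phenyl ring therefore does not by itself preserve the number of compound 1: a 3.6-fold higher number from compound 3 to compound 4 (0.56 log units; beyond the scatter) and a 3.8-fold higher number from compound 2 to compound 4 (0.59 log units; beyond the scatter) run in the same direction, so compound 4 stands behind both the 3,5-difluorophenyl of compound 3 and the cyclopropyl of compound 2, which carries no phenyl ring at all. Among these compounds, the outcome at this position thus depends on the single group on the ring, and nothing measured here accounts for the size of this step.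

The compounds shown leave open whether the low number of compound 1 belongs to bromo in particular or whether methoxy is the exception, a question that chloro, methyl or the unsubstituted phenyl ring at the same place could help settle. They also leave open whether a hydroxy or an amine on the ring would follow methoxy or bromo in this assay.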